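Changing One Ring Group on a Shared Core

A few compounds are considered here, and "the series" means these few. Any claim that something is new, unique, unknown or untested is made for them only; others in the source may bear on it.

Compound 1 `Cc1nc2c3ccccc3ccc2c2nc3c(ccc4ccccc43)c(-c3cccnc3)c12` and compound 2 `COc1ccc(-c2c3ccc4ccccc4c3nc3c2c(C)nc2c4ccccc4ccc32)cc1` share one core and differ in a single group. In a functional assay, with a stated time of 90 s (on this read-out lower numbers stand for stronger inhibition and higher numbers for weaker inhibition), compound 1 gives 156 ug/mL, the lowest of the two numbers shown, and compound 2 gives 176 ug/mL; the step of a 1.1-fold higher number from compound 1 to compound 2 (0.05 log units; within the scatter) shows that exchanging this group left the read-out essentially unchanged. Compound 3 `Cc1nc2c3ccccc3ccc2c2nc3c(ccc4ccccc43)c(-c3ccccc3N)c12` arises from compound 1 by 2-aminophenyl in place of pyridin-3-yl on an aromatic carbon. For the measured compounds named here, only the step to compound 2 bears on this, and it stayed within the scatter, so for compound 3 no movement beyond the scatter is expected: a 1.0-fold higher number from compound 1 to compound 3 (0.01 log units; within the scatter). Compound 3 is therefore estimated at 160 ug/mL, within 80 ug/mL to 320 ug/mL.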

Compound 3, half-maximal inhibitory concentration: 125 ug/mL
For compound 3 the middle estimate is 1.3-fold (0.11 log units) above the measured one; low and high end bracket the measured number.
By their numbers in this assay, from the lowest: compounds 3, 1 and 2 (each within the scatter of the next).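

Replacing pyridin-3-yl with 2-aminophenyl gives a 1.2-fold lower number from compound 1 to compound 3 (0.10 log units; within the scatter) in this assay and, against the other aryl group, a 1.4-fold lower number from compound 2 to compound 3 (0.15 log units; within the scatter) in the same read-out. This position therefore accepts a third ring group, here a carbon-only aromatic ring with a hydrogen-bond donor, and the number still does not move beyond the scatter. No supporting measurement is available to explain this flat result.

From the compounds shown here alone, it remains open whether a group without an aromatic ring, such as a carboxylic acid or a longer alkyl chain, would shift the number at this carbon. Changes elsewhere on the shared core also remain open.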